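The compounds below may be only part of what the source reports. "The series", "measured", "known", "first", "only" and "open" are said of these compounds alone.

For the measured compounds named here, both compounds so far were measured in a functional assay on RBL-2H3 cells (Rattus norvegicus) for inhibition; on this read-out lower numbers stand for stronger inhibition and higher numbers for weaker inhibition. Compound 1 `Cc1csc(N/C(S)=N/[C@@H](C)c2cccc3ccccc23)n1` gives 83200 nM in this assay. Compound 2 `C[C@@H](/N=C(\S)Nc1ccccn1)c1cccc2ccccc12` gives only a limit of this assay, > 100000 nM. Going by the values given here, compound 2 therefore stands not at a number but at the limit of > 100000 nM in this assay, at which 1 of the 2 values shown sits, so its two-digit neighbour compound 1 cannot be set in order against it, and no step between the two is given here.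

Compound 3 `Cc1cc(C)nc(N/C(S)=N/[C@H](C)c2cccc3ccccc23)c1` has not yet been measured in this assay. It differs from compound 2 in one place: 4,6-dimethylpyridin-2-yl in place of pyridin-2-yl on an amine nitrogen. With compound 2 known only as a limit, the expectation for this change is a step that is small or none beyond the scatter, in no settled direction. The estimated step is an at least 1.1-fold lower number from compound 2 to compound 3 (0.04 log units; that floor lies within the scatter). For compound 3 the estimate in this assay is about 90000 nM, with a range from 30000 nM to 250000 nM.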

Compound 3, half-maximal inhibitory concentration: > 100000 nM
Compound 3: a limit, no number; the forecaster's own chance of this, stated with the estimate: 50%; at least 1.1-fold (0.04 log units) between middle value and limit.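

In this assay compound 3 gives only a limit, > 100000 nM, as compound 2 does, so no step between compound 2 and compound 3 can be read: the limit of > 100000 nM in this assay, at which 2 of the 3 values shown sit.

The compounds shown leave open whether 4,6-dimethylpyridin-2-yl in place of pyridin-2-yl on an amine nitrogen changes the inhibition at all, and in which direction.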